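Methoxy for fluoro on the 4-substituted phenyl

The source may report more compounds than this note shows. Statements on the series, on what has been measured and on what is new or still open speak of the compounds shown alone.

compound 1 `COc1ccccc1NC(=S)N/N=C/c1ccc2ccccc2n1` gives 91700 nM in a functional assay on HL-60 cells (Homo sapiens) for antiproliferative activity, read by sulforhodamine B assay, with a stated time of 72 h; a higher number here means a weaker inhibitor, a lower number a stronger inhibitor
compound 2 `Fc1ccc(NC(=S)N/N=C/c2ccc3ccccc3n2)cc1` gives 17000 nM in this assay
compound 3 `COc1ccc(NC(=S)N/N=C/c2ccc3ccccc3n2)cc1` is not yet measured

Within the data shown here, compound 2 has the lower of the two numbers so far. Compound 3 replaces its fluoro with methoxy on an aromatic carbon, para to a large group (methoxy in place of fluoro on an aromatic carbon). Among the measured compounds shown here, only one measured step bears on this (a 5.4-fold lower number from compound 1 to compound 2 (0.73 log units; beyond the scatter)), modest and beyond the scatter. Compound 1 (91700 nM) also carries methoxy, but at a different place, so that step is only a loose guide. In this assay a smaller step to a higher number is expected (a 1.8-fold higher number from compound 2 to compound 3 (0.25 log units; within the scatter)). Compound 3 is estimated at 30000 nM (range 9000 nM to 90000 nM).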

Compound 3, half-maximal inhibitory concentration: 43800 nM
Compound 3: the middle estimate sits 1.5-fold (0.16 log units) below what was measured; the measured number falls inside the stated range.
By their numbers in this assay, from the lowest: compound 2; then compound 3; then compound 1.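

In this assay, methoxy in place of fluoro on this aromatic carbon gives a 2.6-fold higher number from compound 2 to compound 3 (0.41 log units; beyond the scatter), so the two groups are distinguishable at this position, with fluoro holding the lower number. The group's place also counts: 4-methoxyphenyl in place of 2-methoxyphenyl gives a 2.1-fold lower number from compound 1 to compound 3 (0.32 log units; beyond the scatter). Nothing available explains either step.

From the compounds shown here alone, whether an amine or a carboxylic acid at this place would fall below compound 2 remains open. So does the effect of chloro, which would further test how far fluoro's advantage extends.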